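Replacing fluorine with methyl on a cyclopropyl amide

A few compounds are considered here, and "the series" means these few. Any claim that something is new, unique, unknown or untested is made for them only; others in the source may bear on it.

Compound 1 `O=C([C@H]1C[C@H]1F)N1CC2CC(C1)N2` and compound 2 `O=C([C@@H]1C[C@H]1F)N1CC2CC(C1)N2` have the same atoms and bonds and differ only in how one stereocentre on the cyclopropyl ring is drawn. In an assay on SH-EP1 cells for agonist activity at Neuronal acetylcholine receptor; alpha4/beta2 (Homo sapiens), read by FLIPR and calcium flux (on this read-out lower numbers stand for an effect already at smaller amounts and higher numbers for an effect only at larger amounts of compound), compound 1 gives 1500 nM, and compound 2 gives 870 nM. The step of a 1.7-fold lower number from compound 1 to compound 2 (0.24 log units; within the scatter), so the two compounds stand at the same level; the drawing difference behind this step is the fact that one of compounds 1 and 2 is drawn with a defined configuration and the other without, at the place where they differ. Compound 3 `C[C@H]1C[C@@H]1C(=O)N1CC2CC(C1)N2` has not yet been measured. It differs from compound 2 by 2-methylcyclopropyl in place of 2-fluorocyclopropyl on a carbonyl carbon. No measured step exchanges one substituent on the cyclopropyl ring for another; the only step shown is a change of drawn configuration that stayed within the scatter. For compound 3 in this assay the expected step is therefore a 1.1-fold higher number from compound 2 to compound 3 (0.06 log units; within the scatter), with no measured evidence to lean on for either direction. Compound 3 is estimated at 1000 nM, in a range from 250 nM to 4000 nM.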

Compound 3, half-maximal effective concentration: 14000 nM
Compound 3: the middle estimate sits 14-fold (1.15 log units) below what was measured; the measured number lies above the stated range.
By their numbers in this assay, from the lowest: compounds 2 and 1 (each within the scatter of the next); then compound 3.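

In this assay, the group on the cyclopropyl ring turns out to matter far more than the earlier pair suggested: 2-methylcyclopropyl in place of 2-fluorocyclopropyl on a carbonyl carbon gives a 16-fold higher number from compound 2 to compound 3 (1.21 log units; beyond the scatter) and a 9.3-fold higher number from compound 1 to compound 3 (0.97 log units; beyond the scatter). So this position responds strongly to the exchange, even though compounds 1 and 2 stand level and the two groups carry the same number of heavy atoms and the same ring. For the compounds shown here, nothing at hand bears on why this exchange moves the number so far.

Still open, on these data alone, is whether a chlorine or a hydroxyl on the cyclopropyl ring would stay near compound 2 or move towards compound 3. Also open, as far as these compounds go, is whether the drawn configuration of 2-methylcyclopropyl matters as little as that of 2-fluorocyclopropyl did.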